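The compounds below may be only part of what the source reports. "The series", "measured", "known", "first", "only" and "open" are said of these compounds alone.

In a functional assay on MCF7 cells (Homo sapiens) for antiproliferative activity, read by CellTiter-Glo, with a stated time of 5 days (on this read-out lower numbers stand for stronger inhibition and higher numbers for weaker inhibition), compound 1, with structure `CC/C(=C(/c1ccc(/C=C/C(=O)O)cc1)c1ccc2nccn2c1)c1ccccc1`, gives 170 nM. Compound 2, with structure `CC/C(=C(/c1ccc(/C=C/C(=O)O)cc1)c1ccn2ccnc2c1)c1ccccc1`, reaches only the limit of this assay, recorded as > 500 nM, so its standing is known as a boundary rather than as a number. Among the compounds with values here, the single measured step, an at least 2.9-fold higher number from compound 1 to compound 2 (0.46 log units; beyond the scatter), exchanges one fused aromatic group for another at the same place and shows that this part of the molecule can shift the result, though its size is known only as a floor because of the limit of > 500 nM in this assay, at which 1 of the 2 values shown sits. Compound 3, with structure `CC/C(=C(/c1ccc(/C=C/C(=O)O)cc1)c1ccc2ocnc2c1)c1ccccc1`, differs from compound 2 by a group of 9 heavy atoms (7 carbon, 1 nitrogen, 1 oxygen; one five-membered aromatic ring with 2 hetero atoms, one six-membered aromatic ring of carbon only) in place of a group of 9 heavy atoms (7 carbon, 2 nitrogen; one five-membered aromatic ring with 2 hetero atoms, one six-membered aromatic ring with 1 hetero atom), on a double-bonded chain carbon bound to an aromatic carbon and a double-bonded chain carbon. Within the data shown here, since the one step available, an at least 2.9-fold higher number from compound 1 to compound 2 (0.46 log units; beyond the scatter), gives only a lower bound and the entering group has no measured counterpart, the expected step of an at least 1.6-fold lower number from compound 2 to compound 3 (0.22 log units; that floor lies within the scatter) in this assay is a modest move toward stronger inhibition, held with wide uncertainty. Compound 3 is therefore estimated at 300 nM, within 90 nM to 900 nM.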

Compound 3, half-maximal inhibitory concentration: > 500 nM
Compound 3: no number, only a limit (the forecaster's own chance of this, stated with the estimate: 30%); at least 1.6-fold (0.22 log units) between middle value and limit.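

With 1,3-benzoxazol-5-yl at this place, the result is an at least 2.9-fold higher number from compound 1 to compound 3 (0.46 log units; beyond the scatter) in this assay. Compound 1 now stands clear of two different fused aromatic groups rather than one, and the new group has a six-membered aromatic ring of carbon only, so a ring nitrogen shared with compound 1 and compound 2 is not needed for a result at the limit. The step between compound 2 and compound 3 cannot be read, since both values are limits and not numbers: the limit of > 500 nM in this assay, at which 2 of the 3 values shown sit.

From the compounds shown here alone, how far compound 2 and compound 3 really differ, and how far either lies from compound 1, remains open. Also open, going by these compounds, is whether another fused group at this place, such as indazol-5-yl or quinolin-6-yl, would come close to compound 1 or pass it.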